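Swapping chloro for trifluoromethyl on a succinimide-piperazine amide

This account rests on a few compounds, and the source may have more. Where it says the series, first, only, none or still open, it means among the compounds named here.

Two compounds share a core in which a succinimide ring is joined through a short chain and a carbonyl to a piperazine carrying a chloro-substituted benzene. Compound 1 `CCC(C(=O)N1CCN(c2cccc(Cl)c2)CC1)N1C(=O)CCC1=O` gives 50% in a functional assay on the whole organism (strain Swiss) with Mus musculus as the target, in the maximal electroshock model, with a stated time of 0.5 h, at a dose of 100 mg/kg by the intraperitoneal route; a lower number here means a weaker effect, a higher number a stronger effect of the compound at the dose given. Compound 2 `CC(C(=O)N1CCN(c2cccc(Cl)c2)CC1)N1C(=O)CCC1=O`, in which hydrogen replaces methyl on the saturated chain carbon, gives 75% in this assay. Among the measured compounds shown here, the one measured step is a number 25 percentage points higher from compound 1 to compound 2 (beyond the scatter), so compound 2 holds the higher of the two numbers.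

Compound 3 `CC(C(=O)N1CCN(c2cccc(C(F)(F)F)c2)CC1)N1C(=O)CCC1=O` is not yet measured. It differs from compound 2 by trifluoromethyl in place of chloro on an aromatic carbon, the new group sitting on the aromatic carbon meta to a large group. For the measured compounds named here, no measured step touches this part of the molecule: the only step measured concerns the chain, not the aromatic ring, so it gives no direct guide to the size or direction of this change. With nothing pointing either way, the sensible expectation is a number close to that of compound 2, with no step beyond the scatter. Compound 3 is therefore expected to give about 70%, somewhere between 45% and 95%. That estimate corresponds to a step of a number 5 percentage points lower from compound 2 to compound 3 (within the scatter), which stays inside the scatter.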

Compound 3, a percentage reported as activity, at one dose (the size of the read-out at that dose, not a potency): 75%
Beside the measured number, compound 3's estimate is 5 percentage points below it, and the stated range covers the measured number.
By their numbers in this assay, from the lowest: compound 1; then compounds 2 and 3 (each within the scatter of the next).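

Among the compounds shown here, the only step measured before this one lay on the chain, so the aromatic ring had not yet been probed. In this assay, swapping chloro for trifluoromethyl on this aromatic carbon, meta to a large group, gives no change at the digits printed from compound 2 to compound 3 (within the scatter), whereas the chain change gave a number 25 percentage points higher from compound 1 to compound 2 (beyond the scatter). So at this position, a group of 4 heavy atoms can replace a group of 1 heavy atom with no shift that can be told from the scatter, and no measurement of any property of these groups is available to account for this result.

Only these two groups are shown at this position, and only at one dose and one time, so it remains open whether a methoxy group, an amine or plain hydrogen on the same aromatic carbon would leave the read-out where it is. As far as these compounds go, it is also open whether the same swap would give a similar result on the core of compound 1, with its longer chain.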